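The source may report more compounds than this note shows. Statements on the series, on what has been measured and on what is new or still open speak of the compounds shown alone.

Compound 1 `O=C(Nc1cccc(-n2cc(-c3ccncc3)c(-c3ccc(Cl)c(O)c3)n2)c1)Nc1ccc(Cl)c(Cl)c1` and compound 2 `COc1cc(-c2nn(-c3cccc(NC(=O)c4ccc(Cl)c(C(F)(F)F)c4)c3)cc2-c2ccncc2)ccc1Cl` share a core. In a functional assay on RPMI-8226 cells (Homo sapiens) for inhibition, read by sulforhodamine B assay, with a stated time of 48 h (on this read-out lower numbers stand for stronger inhibition of growth and higher numbers for weaker inhibition of growth), compound 1 gives only a limit of the assay, > 32500 nM. In this assay compound 2 likewise gives only a limit, > 32500 nM. Within the data shown here, compound 2 thus stands on no numbered scale, and the single other value shown beside it is also a limit, both resting at the limit of > 32500 nM in this assay, at which 2 of the 2 values shown sit. Compound 3 `COc1cc(-c2nn(-c3cccc(NC(=O)c4cccc(C(F)(F)F)c4)c3)cc2-c2ccncc2)ccc1Cl` differs from compound 2 by hydrogen in place of chloro on an aromatic carbon, chloro leaving and hydrogen entering. Among the measured compounds shown here, with no measured step at hand, no shift beyond the scatter in this assay is expected in either direction. Compound 3 is estimated at 40000 nM, within 15000 nM to 100000 nM. The expected step is a step that the limit leaves unreadable from compound 2 to compound 3.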

Compound 3, concentration for total growth inhibition: 26600 nM
The estimate for compound 3 lay 1.5-fold (0.18 log units) above the measured number, and the stated range covers the measured number.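

With hydrogen in place of chloro on this aromatic carbon, compound 3 is the only compound shown that carries a number rather than a limit in this assay. The change gives an at least 1.2-fold lower number from compound 2 to compound 3 (0.08 log units; that floor lies within the scatter), so the shift is not shown to exceed the scatter, and its true size cannot be read. The other values remain limits: the limit of > 32500 nM in this assay, at which 2 of the 3 values shown sit.

The compounds shown leave open how a fluoro, a methoxy or an amine would read at this position. They also leave open what replacing the neighbouring trifluoromethyl group with a nitrile would do.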